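Working notes: halogen exchange on the anilide ring

This account rests on a few compounds, and the source may have more. Where it says the series, first, only, none or still open, it means among the compounds named here.

Measured so far in a functional assay on the whole organism (strain Wistar) for inhibition, with Rattus norvegicus as the target, read by paw edema, with a stated time of 3 h, at a dose of 100 mg/kg; a lower number here means less inhibition, a higher number more inhibition at the dose given (going by the name of the read-out):
compound 1 `COc1cc2c(cc1OC)C(CC(=O)O)CC2`, 27.5%
compound 2 `COc1cc2c(cc1OC)C(CC(=O)Nc1ccc(Cl)cc1)CC2`, 60.9%

Compound 2 stands highest of the two numbers; the nearest is compound 1, and the step of a number 33.4 percentage points higher from compound 1 to compound 2 (beyond the scatter) is large and beyond the scatter. Compound 3 `COc1cc2c(cc1OC)C(CC(=O)Nc1ccc(Br)cc1)CC2` is not yet measured. It differs from compound 2 by bromo in place of chloro on an aromatic carbon. Within the data shown here, the only measured step, a number 33.4 percentage points higher from compound 1 to compound 2 (beyond the scatter), concerns a different part of the molecule, the group on the carbonyl carbon, so no measured step bears on an exchange of one halogen for another on the aromatic ring, and the series itself gives no guide to the size of such a change. With nothing in the data to move the number, the step of a number 0.9 percentage points lower from compound 2 to compound 3 (within the scatter) is expected to stay within the scatter. Compound 3 is therefore estimated at 60%, with a range of 45% to 75%.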

Compound 3, a percentage reported as inhibition, in the whole organism at one dose (the size of the read-out at that dose, not a potency): 43.5%
Compound 3: the middle estimate sits 16.5 percentage points above what was measured, outside the stated range (below it).
By their numbers in this assay, from the lowest: compound 1; then compound 3; then compound 2.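

In this assay the aromatic carbon bearing the halogen proves sensitive to a one-atom exchange: bromo in place of chloro gives a number 17.4 percentage points lower from compound 2 to compound 3 (beyond the scatter) and so removes a sizeable part of what the anilide had gained. The gain over the free acid therefore depends on the halogen and not on the anilide alone, standing at a number 16 percentage points higher from compound 1 to compound 3 (beyond the scatter) with bromo against a number 33.4 percentage points higher from compound 1 to compound 2 (beyond the scatter) with chloro. Nothing available accounts for the difference between the two halogens.

Going by these compounds, two halogens cannot show whether the number follows a trend across the halogens, so fluoro and iodo at this place remain open. Also open, on these data alone, is how a methoxy group, an amine or a plain unsubstituted phenyl ring would compare there with compound 2.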